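Removing the Aryl Methyl in a Quinoline Thiosemicarbazone Series

The source may hold more compounds than are shown below. What is called first, only, known or untested is meant among the compounds shown, and "the series" means these compounds.

Compound 3 `Cc1ccc(NC(=S)N/N=C/c2ccc3ccccc3n2)cc1` carries a 4-methylphenyl on the amide-type nitrogen of the shared core. In a functional assay on HT-29 cells (Homo sapiens) for antiproliferative activity, read by sulforhodamine B assay, with a stated time of 72 h (a higher number here means a weaker inhibitor, a lower number a stronger inhibitor), compound 3 gives 85500 nM, the second highest of the three numbers measured. Its nearest neighbour is compound 1 `NC(=S)N/N=C/c1ccc2ccccc2n1`, which in this assay gives 100000 nM; the two differ by a 1.2-fold lower number from compound 1 to compound 3 (0.07 log units; within the scatter). Compound 2 `N#Cc1ccc(NC(=S)N/N=C/c2ccc3ccccc3n2)cc1` gives 15600 nM in this assay, and the step of a 5.5-fold higher number from compound 2 to compound 3 (0.74 log units; beyond the scatter) is the only one here beyond the scatter that touches compound 3; the step of a 6.4-fold lower number from compound 1 to compound 2 (0.81 log units; beyond the scatter) shows the same separation from the other side.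

Compound 4 `S=C(N/N=C/c1ccc2ccccc2n1)Nc1ccccc1` differs from compound 3 by hydrogen in place of methyl on an aromatic carbon. For the measured compounds named here, no measured step removes this methyl alone. The step of a 1.2-fold lower number from compound 1 to compound 3 (0.07 log units; within the scatter) shows that adding the whole 4-methylphenyl barely moves the number, so the expectation is that taking the methyl off again leaves compound 4 near compound 3, within the scatter. For compound 4 the estimated step is a 1.2-fold lower number from compound 3 to compound 4 (0.09 log units; within the scatter), giving an expected value of 70000 nM with a range from 25000 nM to 100000 nM.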

Compound 4, half-maximal inhibitory concentration: 17000 nM
Compound 4: middle estimate off by 4.1-fold (0.61 log units), on the high side, and the stated range ends above it.
By their numbers in this assay, from the lowest: compounds 2 and 4 (each within the scatter of the next); then compounds 3 and 1 (each within the scatter of the next).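

In this assay, for the compounds shown here, removing the single carbon of the methyl counts for far more than the earlier steps suggested (a 5.0-fold lower number from compound 3 to compound 4 (0.70 log units; beyond the scatter)), so this place, para to a large group, is not indifferent to what it carries. The unsubstituted phenyl also separates from the core of compound 1 (a 5.9-fold lower number from compound 1 to compound 4 (0.77 log units; beyond the scatter)), which means the near absence of change on adding 4-methylphenyl held only with the methyl present. Hydrogen and cyano at this place cannot be told apart (a 1.1-fold higher number from compound 2 to compound 4 (0.04 log units; within the scatter)), so among the three groups shown, methyl alone stands apart.

Nothing available explains why this methyl moves the number as it does. Going by these compounds, whether an ethyl, a methoxy or an amine at this place would group with methyl or with hydrogen and cyano stays open.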